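Methyl for Hydrogen, Repeated on a Second Arm

The compounds below may be only part of what the source reports. "The series", "measured", "known", "first", "only" and "open" are said of these compounds alone.

Compound 1 `Cc1nc(C)c(CN2CCN(c3cccc4[nH]c(-c5ccc(C(C)(C)C)cc5)nc34)CC2)s1` is the starting point, and in an assay on isolated protein for displacement of a labelled ligand from Gonadotropin-releasing hormone receptor (Homo sapiens) (a lower number here means a stronger inhibitor, a higher number a weaker inhibitor), compound 1 gives 27 nM. Compound 2 `CCc1nc(C)c(CN2CCN(c3cccc4[nH]c(-c5ccc(C(C)(C)C)cc5)nc34)CC2)s1` differs from it by methyl in place of hydrogen on a saturated chain carbon bound to an aromatic carbon, and in this assay compound 2 gives 20 nM; the step is a 1.4-fold lower number from compound 1 to compound 2 (0.13 log units; within the scatter). Compound 3 `Cc1cc(CN2CCN(c3cccc4[nH]c(-c5ccc(C(C)(C)C)cc5)nc34)CC2)nn1C` differs from compound 1 by 1,5-dimethyl-1H-pyrazol-3-yl in place of 2,4-dimethyl-1,3-thiazol-5-yl on a saturated chain carbon bound to an amine nitrogen in a ring. In this assay compound 3 gives 83 nM. That swap of the arm gave a 3.1-fold higher number from compound 1 to compound 3 (0.49 log units; beyond the scatter) and, against the ethyl analogue, a 4.2-fold higher number from compound 2 to compound 3 (0.62 log units; beyond the scatter), so compound 3 has the highest number of the three measured compounds.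

Compound 4 `CCc1cc(CN2CCN(c3cccc4[nH]c(-c5ccc(C(C)(C)C)cc5)nc34)CC2)nn1C` has not yet been measured. It differs from compound 3 by methyl in place of hydrogen on a saturated chain carbon bound to an aromatic carbon, the same change at the same kind of place that turned compound 1 into compound 2. Because that earlier step was a 1.4-fold lower number from compound 1 to compound 2 (0.13 log units; within the scatter), a step of similar size is expected here, a 1.3-fold lower number from compound 3 to compound 4 (0.11 log units; within the scatter), though this rests on a single precedent on a different arm. Compound 4 is therefore estimated at 65 nM in this assay, expected to fall between 30 nM and 140 nM.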

Compound 4, half-maximal inhibitory concentration: 43 nM
For compound 4 the middle estimate is 1.5-fold (0.18 log units) above the measured one, and the stated range covers the measured number.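

In this assay the change from methyl to ethyl on the pyrazolyl arm gave a 1.9-fold lower number from compound 3 to compound 4 (0.29 log units; within the scatter) and the result agrees with the same change on the thiazolyl arm: the same change on two cores in this assay, a 1.4-fold lower number (0.13 log units; within the scatter) from compound 1 to compound 2 and a 1.9-fold lower number (0.29 log units; within the scatter) from compound 3 to compound 4, 1.4-fold (0.16 log units) apart, within the scatter of two such steps.

The change therefore carried from one core to the other with no detectable difference in size, yet each step alone lies within the scatter, so these two pairs show neither a real gain from ethyl on either arm nor how the change would behave on a third core. The choice of arm can still matter: with ethyl on both arms the swap gave a 2.2-fold higher number from compound 2 to compound 4 (0.33 log units; beyond the scatter) and lies beyond the scatter, while a 1.6-fold higher number from compound 1 to compound 4 (0.20 log units; within the scatter) stays within it, so compound 4 cannot be told apart from the methyl thiazolyl compound.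

Open, going by these compounds, is whether a longer chain such as propyl, or a branched one such as isopropyl, at this place would give a step beyond the scatter on either arm. Also open, on these data alone, is how a hydroxyl or an amine at the end of that chain would fare.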